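A fluoro gives way to two methyls on the amide aryl

The compounds below may be only part of what the source reports. "The series", "measured", "known", "first", "only" and "open" are said of these compounds alone.

Compound 3 `O=C(Nc1cccc(-c2oc3cc(-c4ccc(F)cc4)ccc3c(=O)c2O)c1)c1cccc(F)c1` gives 2510 nM in a functional assay on MDA-MB-231 cells (Homo sapiens) for antiproliferative activity, read by CCK-8 assay, with a stated time of 72 h (a higher number here means a weaker inhibitor, a lower number a stronger inhibitor), the lowest of the three numbers at hand. Compound 1 `O=C(Nc1cccc(-c2oc3cc(-c4ccc(F)cc4)ccc3c(=O)c2O)c1)c1ccccc1F` gives 7240 nM and compound 2 `Cc1ccccc1C(=O)Nc1cccc(-c2oc3cc(-c4ccc(F)cc4)ccc3c(=O)c2O)c1` gives 4910 nM in this assay; the step of a 2.9-fold lower number from compound 1 to compound 3 (0.46 log units; beyond the scatter) lies beyond the scatter, whereas a 2.0-fold lower number from compound 2 to compound 3 (0.29 log units; within the scatter) and a 1.5-fold lower number from compound 1 to compound 2 (0.17 log units; within the scatter) do not. Compound 4 `Cc1cc(C)cc(C(=O)Nc2cccc(-c3oc4cc(-c5ccc(F)cc5)ccc4c(=O)c3O)c2)c1` differs from compound 3 by 3,5-dimethylphenyl in place of 3-fluorophenyl on a carbonyl carbon. For the measured compounds named here, the one measured step that bears on a methyl replacing a fluoro, a 1.5-fold lower number from compound 1 to compound 2 (0.17 log units; within the scatter), stayed within the scatter, and no measured pair tests a second methyl on that ring. Compound 4 is therefore expected to show a 1.1-fold higher number from compound 3 to compound 4 (0.05 log units; within the scatter), no step beyond the scatter. Compound 4 is estimated at 2800 nM, with a range from 1200 nM to 6500 nM.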

Compound 4, half-maximal inhibitory concentration: 11900 nM
Estimate against measurement, compound 4: 4.3-fold (0.63 log units) below; the whole stated range lies below it.
By their numbers in this assay, from the lowest: compounds 3, 2, 1 and 4 (each within the scatter of the next, the first and the last beyond it).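

In this assay, for the compounds shown here, the aryl group on this carbonyl carbon turns out to tolerate a methyl swap less freely than the earlier compounds suggested: 3,5-dimethylphenyl gives a 4.7-fold higher number from compound 3 to compound 4 (0.68 log units; beyond the scatter) and a 2.4-fold higher number from compound 2 to compound 4 (0.38 log units; beyond the scatter), both beyond the scatter. Against 2-fluorophenyl, however, it gives a 1.6-fold higher number from compound 1 to compound 4 (0.22 log units; within the scatter), so compound 4 cannot be separated from compound 1. Nothing at hand accounts for these steps.

Going by these compounds, it remains open whether the step follows the lost fluorine or the added methyls. Also open, on these data alone, is how a plain phenyl, or a phenyl carrying an amine or a carboxylic acid, would read on this carbonyl carbon.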